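Notes on the amine-to-benzyloxy change in this series

A few compounds are considered here, and "the series" means these few. Any claim that something is new, unique, unknown or untested is made for them only; others in the source may bear on it.

Measured in a functional assay on L02 cells (Homo sapiens) for inhibition, read by Griess assay, with stated times of 1 h and 24 h; on this read-out higher numbers stand for weaker inhibition and lower numbers for stronger inhibition:
compound 1 `COc1ccc(Nc2nc(/C=C/c3cc(OC)c(OC)c(OC)c3)nc3ccsc23)cc1`: 279000 nM
compound 2 `COc1cc(/C=C/c2nc(Nc3ccc(C(F)(F)F)cc3)c3sccc3n2)cc(OC)c1OC`: 436000 nM
compound 3 `COc1cc(/C=C/c2nc(NCc3ccncc3)c3sccc3n2)cc(OC)c1OC`: 374000 nM

Compound 3 lies within the scatter of both other compounds: a 1.3-fold higher number from compound 1 to compound 3 (0.13 log units; within the scatter) and a 1.2-fold lower number from compound 2 to compound 3 (0.07 log units; within the scatter); the remaining pair shows a 1.6-fold higher number from compound 1 to compound 2 (0.19 log units; within the scatter). Compound 4 `COc1cc(/C=C/c2nc(OCc3ccccc3)c3sccc3n2)cc(OC)c1OC` is unmeasured; the change is benzyloxy in place of ((pyridin-4-yl)methyl)amino on an aromatic carbon. Within the data shown here, the steps that bear on it are the two that exchanged the group at the same place, from compound 1 to compound 3 and from compound 2 to compound 3, both within the scatter. Among the measured compounds shown here, no measured step exchanges the nitrogen for an oxygen, so that part of the change is untested here. The step is expected to be a 1.0-fold higher number from compound 3 to compound 4 (0.01 log units; within the scatter), nothing beyond the scatter. Compound 4 is expected at 380000 nM, within 150000 nM to 950000 nM.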

Compound 4, half-maximal inhibitory concentration: > 1000000 nM
Compound 4 was reported as a limit; the forecaster's own chance of this, stated with the estimate: 10%; middle value at least 2.6-fold (0.42 log units) away from the limit.
By their numbers in this assay, from the lowest: compounds 1, 3 and 2 (each within the scatter of the next). At a limit, above all of these: compound 4.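

Compound 4 is reported as a limit of the assay, not as a number: the limit of > 1000000 nM in this assay, at which 1 of the 4 values shown sits. Its steps from the three amines all lie beyond the scatter: an at least 2.6-fold higher number from compound 3 to compound 4 (0.42 log units; beyond the scatter), an at least 2.2-fold higher number from compound 2 to compound 4 (0.36 log units; beyond the scatter) and an at least 3.5-fold higher number from compound 1 to compound 4 (0.55 log units; beyond the scatter). Exchanges among the amino groups at this place stayed within the scatter, so benzyloxy gives the first change here that moves toward weaker inhibition in this assay.

The step from compound 3 to compound 4 changes the linking atom and the ring together, and the compounds shown do not separate the two. A benzylamino group or a (pyridin-4-yl)methoxy group would bear on that question.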